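This account rests on a few compounds, and the source may have more. Where it says the series, first, only, none or still open, it means among the compounds named here.

Compound 1 `Clc1ccc(C2=NN(c3ccc(-c4ccccc4)nn3)C(c3ccc(Cl)cc3)C2)cc1` gives 8800 nM in a functional assay on MCF7 cells (Homo sapiens) for antiproliferative activity, read by MTT assay, with a stated time of 24 h; a lower number here means a stronger inhibitor, a higher number a weaker inhibitor.
Compound 2 `Fc1ccc(C2CC(c3ccc(Cl)cc3)=NN2c2ccc(-c3ccccc3)nn2)cc1` gives 3750 nM in this assay.
Compound 3 `COc1ccc(C2=NN(c3ccc(-c4ccccc4)nn3)C(c3ccc(Cl)cc3)C2)cc1` gives 58000 nM in this assay.

Compound 3 has the highest number of the three in this assay; its core differs from that of compound 1 by methoxy in place of chloro on an aromatic carbon, a change that gave a 6.6-fold higher number from compound 1 to compound 3 (0.82 log units; beyond the scatter). Compound 2 differs from compound 1 by fluoro in place of chloro on an aromatic carbon, and that change gave a 2.3-fold lower number from compound 1 to compound 2 (0.37 log units; beyond the scatter).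

Compound 4 `COc1ccc(C2=NN(c3ccc(-c4ccccc4)nn3)C(c3ccc(F)cc3)C2)cc1` is not yet measured in this assay. It differs from compound 3 by fluoro in place of chloro on an aromatic carbon, the same change as from compound 1 to compound 2, made on a different core. For the measured compounds named here, the expectation for compound 4 rests on this single earlier case: with only one measured example of the change, the step is expected to be of similar size, so compound 4 is expected to show a 2.3-fold lower number from compound 3 to compound 4 (0.37 log units; beyond the scatter) in this assay. Compound 4 is therefore estimated at 25000 nM in this assay, with a range from 10000 nM to 70000 nM.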

Compound 4, half-maximal inhibitory concentration: 20000 nM
Compound 4: middle estimate off by 1.3-fold (0.10 log units), on the high side, and the stated range covers the measured number.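

In this assay, fluoro in place of chloro, the 4-chlorophenyl to 4-fluorophenyl change, gave a 2.9-fold lower number from compound 3 to compound 4 (0.46 log units; beyond the scatter), and the step carried over from the core of compound 1 to the core of compound 3 with no difference beyond the scatter: the same change on two cores in this assay, a 2.3-fold lower number (0.37 log units; beyond the scatter) from compound 1 to compound 2 and a 2.9-fold lower number (0.46 log units; beyond the scatter) from compound 3 to compound 4, 1.2-fold (0.09 log units) apart, within the scatter of two such steps. Methoxy in place of chloro gave a 5.3-fold higher number from compound 2 to compound 4 (0.73 log units; beyond the scatter), and this step also held on both cores: the same change on two cores in this assay, a 6.6-fold higher number (0.82 log units; beyond the scatter) from compound 1 to compound 3 and a 5.3-fold higher number (0.73 log units; beyond the scatter) from compound 2 to compound 4, 1.2-fold (0.09 log units) apart, within the scatter of two such steps. The two changes therefore behaved independently across these four compounds, but this is one closed set in which the cores differ in a single group, so it does not show that either step would carry over to a more distant core, and it gives no reason for the size of either step.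

The compounds shown leave open whether an amine, a carboxylic acid or a longer alkyl chain in these places would follow the same independent behaviour. They also leave open whether the steps would persist if the phenyl group on the shared core were replaced.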